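A Carbonyl Chain Replaces an Aryl on the Ring Nitrogen

The source may report more compounds than this note shows. Statements on the series, on what has been measured and on what is new or still open speak of the compounds shown alone.

Compound 1, `COc1ccc(-c2cnc3nc(N)nc(N4CCN(c5ccc(F)cc5)CC4)c3n2)cc1OC`, is the starting point of this comparison. In a functional assay on cells (T-cell, Homo sapiens) for inhibition (a lower number here means a stronger inhibitor, a higher number a weaker inhibitor), compound 1 gives 100 nM, the lower of the two numbers measured in that assay. Its nearest measured neighbour is compound 3, `COc1ccc(-c2cnc3nc(N)nc(NCc4cccs4)c3n2)cc1OC`, which in this assay gives 4100 nM, a gap that lies well beyond the usual scatter of repeated measurements. Compound 2, `CC(C)Oc1nc(N)nc2ncc(-c3ccc(C(F)(F)F)cc3)nc12`, returns only a limit in this assay, > 10000 nM, so no number is known for it; this is the limit of > 10000 nM in this assay, at which 1 of the 3 values shown sits.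

Compound 4, `COc1ccc(-c2cnc3nc(N)nc(N4CCN(C(=O)CCc5ccccc5)CC4)c3n2)cc1OC`, keeps the core of compound 1 and differs from it in a single place: phenethylcarbonyl in place of 4-fluorophenyl on an amine nitrogen in a ring. Among the measured compounds shown here, no measured pair in this small set makes the same change, so the size of its effect cannot be read off from the data and has to be estimated. The expectation is a step toward a higher number, weaker inhibition, of modest size, although a result inside the scatter would not be surprising. The step expected in this assay is a 4.0-fold higher number from compound 1 to compound 4 (0.60 log units; beyond the scatter). Compound 4 is therefore estimated at 400 nM, with a likely range from 80 nM to 3000 nM.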

Compound 4, half-maximal inhibitory concentration: 100 nM
Estimate against measurement, compound 4: 4.0-fold (0.60 log units) above, and the stated range covers the measured number.
By their numbers in this assay, from the lowest: compounds 1 and 4 (each within the scatter of the next); then compound 3. At a limit, above all of these: compound 2.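

In this assay the result is no change at the digits printed from compound 1 to compound 4 (within the scatter) when phenethylcarbonyl takes the place of 4-fluorophenyl on an amine nitrogen in a ring. Among the compounds shown here, until now only one group had been seen on this nitrogen, and the two now compared are quite different in kind: one is a plain aromatic ring, while the other is a larger chain with a carbonyl, counting one hydrogen-bond acceptor where 4-fluorophenyl counts none, and neither that difference in size nor that acceptor moves the number beyond the scatter. Nothing in the data at hand explains why these two groups give matching values.

From the compounds shown here alone, both groups still hold a six-membered aromatic ring of carbon only, so it remains open whether that ring matters at all, a question that a plain acetyl or a methyl group on the same nitrogen would address. Also open, going by these compounds, is how far the chain itself can vary, for instance with a shorter benzoyl group, a longer chain, or a chain carrying an amine or a carboxylic acid.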